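The compounds below may be only part of what the source reports. "The series", "measured", "known", "first", "only" and "open" are said of these compounds alone.

Of the compounds shown here, three that share one core have been measured in a functional assay with Alpha-1A adrenergic receptor (Homo sapiens) as the target, read by calcium flux; on this read-out higher numbers stand for larger maximal responses and lower numbers for smaller maximal responses. Compound 1 `c1ccc(-c2cnccn2)c(OCC2=NCCN2)c1` gives 97%. Compound 2 `c1csc(-c2ccccc2OCC2=NCCN2)c1` gives 101%, and compound 3 `c1ccc(-c2ccoc2)c(OCC2=NCCN2)c1` gives 104%. The number of compound 3 is the highest of the three, but this says little: its nearest neighbour is reached by a number 3 percentage points higher from compound 2 to compound 3 (within the scatter), its furthest by a number 7 percentage points higher from compound 1 to compound 3 (within the scatter), and the remaining pair shows a number 4 percentage points higher from compound 1 to compound 2 (within the scatter). Going by the values given here, every one of these steps lies within the scatter, so no compound can be set above another.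

Compound 4 `c1ccc(-c2nccs2)c(OCC2=NCCN2)c1` differs from compound 3 in one place: 1,3-thiazol-2-yl in place of furan-3-yl on an aromatic carbon. The three measured steps all swap one five-membered aromatic ring for another on the same aromatic carbon, and none of them moved the number beyond the scatter. The same is therefore expected here, with no step beyond the scatter in this assay in either direction. Compound 4 is estimated at 101%, with a range from 88% to 114%. This estimate means an expected step of a number 3 percentage points lower from compound 3 to compound 4 (within the scatter), within the scatter.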

Compound 4, largest response reached (reported as maximum), in percent of the reference or control that the assay uses: 102%
Compound 4: middle estimate off by 1 percentage points, on the low side; the range from low to high includes it.
By their numbers in this assay, from the lowest: compounds 1, 2, 4 and 3 (each within the scatter of the next).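

In this assay, going by these compounds alone, compound 4 brings to this aromatic carbon a five-membered aromatic ring with 2 hetero atoms, which none of the earlier compounds carried, and all its steps stay within the scatter (a number 2 percentage points lower from compound 3 to compound 4 (within the scatter)), (a number 1 percentage points higher from compound 2 to compound 4 (within the scatter)) and (a number 5 percentage points higher from compound 1 to compound 4 (within the scatter)). The change from furan-3-yl to 1,3-thiazol-2-yl raises the count of hydrogen-bond acceptors in the group, and this goes with no step beyond the scatter, so the four aromatic rings at this place cannot be set apart. No supporting measurement bears on this result.

Going by these compounds, it remains open whether a group that is not an aromatic ring, such as an amine or a carboxylic acid, would move the number beyond the scatter at this place. The compounds shown also do not tell whether any ring atom matters here.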